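Swapping a chlorophenyl for a dimethoxyphenyl on a sulfonamide chain

A few compounds are considered here, and "the series" means these few. Any claim that something is new, unique, unknown or untested is made for them only; others in the source may bear on it.

Measured compounds:
- compound 1, `O=S(=O)(NCCCNCc1ccccc1Cl)c1cc(C(F)(F)F)cc(C(F)(F)F)c1`, gives 11000 nM in a functional assay on BXPC-3 cells (Homo sapiens) for inhibition, read by MTT assay, with a stated time of 72 h; a higher number here means a weaker inhibitor of growth, a lower number a stronger inhibitor of growth
- compound 2, `O=S(=O)(NCCNCc1ccc(-c2ccccc2)cc1)c1cc(C(F)(F)F)cc(C(F)(F)F)c1`, gives 1600 nM in this assay
- compound 3, `O=S(=O)(NCCCCNCc1ccc(Br)cc1)c1cc(C(F)(F)F)cc(C(F)(F)F)c1`, gives 1700 nM in this assay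

Of these three, compound 1 stands highest in this assay, which means it is the weakest inhibitor of growth among them; its nearest neighbour is compound 3 and its furthest is compound 2, and both steps away from it lie beyond the scatter.

Compound 4, `COc1ccc(CNCCCNS(=O)(=O)c2cc(C(F)(F)F)cc(C(F)(F)F)c2)cc1OC`, has not yet been measured. It differs from compound 1 by one change: 3,4-dimethoxyphenyl in place of 2-chlorophenyl on a saturated chain carbon bound to an amine nitrogen.

For the measured compounds named here, only one measured step bears on this change, and only loosely. Going from compound 1 to compound 3 also replaces the chloro-substituted benzyl group, and that step was a 6.5-fold lower number from compound 1 to compound 3 (0.81 log units; beyond the scatter). Compound 2, which likewise carries a different benzyl group and a different chain, gives a lower number than compound 1 as well. In every shown case, leaving the 2-chlorobenzyl arrangement of compound 1 has gone with a lower number, though each of those compounds changes the chain too.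

Compound 4 is therefore expected to give a lower number than compound 1, a modest step of about a 2.4-fold lower number from compound 1 to compound 4 (0.39 log units; beyond the scatter). The estimate for compound 4 in this assay is 4500 nM, with a range from 1500 nM to 14000 nM.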

Compound 4, concentration for 50% growth inhibition: 13000 nM
Compound 4: middle estimate off by 2.9-fold (0.46 log units), on the low side; the measured number falls inside the stated range.
By their numbers in this assay, from the lowest: compounds 2 and 3 (each within the scatter of the next); then compounds 1 and 4 (each within the scatter of the next).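

In this assay, 3,4-dimethoxybenzyl in place of 2-chlorobenzyl gives a 1.2-fold higher number from compound 1 to compound 4 (0.07 log units; within the scatter). This is the first comparison shown in which the chain stays the same and only the aromatic group differs, and here the two groups cannot be told apart. Leaving the 2-chlorobenzyl group is therefore not enough on its own to give a lower number, so the pattern suggested by compound 2 and compound 3, which also differ in their chains, does not hold for compound 4, and no measurement that could explain this result is available.

The compounds shown leave open how much of the lower numbers of compound 2 and compound 3 belongs to the chain and how much to the aromatic group, a question that a 4-bromobenzyl group on the chain of compound 1 would address directly. They also leave open whether this position tolerates every change equally, since a carboxylic acid, a nitrile or a pyridine ring here could still separate from compound 1.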